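A few compounds are considered here, and "the series" means these few. Any claim that something is new, unique, unknown or untested is made for them only; others in the source may bear on it.

For the measured compounds named here, in an ADME assay on the whole organism (plasma) for pharmacokinetics, with Rattus norvegicus as the target (on this read-out lower numbers stand for slow clearance and higher numbers for fast clearance), compound 3 (`O=S(=O)(c1ccc(F)cc1)c1cc(F)c(O)c2ncccc12`) gives the second highest of the three numbers so far (12 mL/min/kg). Compound 1 (`O=S(=O)(c1ccc(O)c2ncccc12)C1CCCC1`) gives a higher number (26 mL/min/kg), and compound 2 (`O=S(=O)(c1ccc(F)cc1)c1cc(Cl)c(O)c2ncccc12`) gives a much lower one (0.31 mL/min/kg).

Compound 4 (`O=S(=O)(c1cc(F)c(O)c2ncccc12)C1CCCC1`) has cyclopentyl in place of 4-fluorophenyl on a sulfonyl sulfur. Going by the values given here, no measured step covers this exchange. Among the compounds with values here, the only measured step (a 39-fold higher number from compound 2 to compound 3 (1.59 log units; beyond the scatter)) is fluoro in place of chloro on an aromatic carbon, which shows that this assay can move a long way but gives no direction for the new change. The nearest guide is compound 1 (26 mL/min/kg), which carries the same cyclopentyl but lacks the fluoro, and whose number lies not far from that of compound 3 (12 mL/min/kg). A small upward step, not beyond the scatter, is therefore expected (a 1.5-fold higher number from compound 3 to compound 4 (0.18 log units; within the scatter)). With so little evidence, the range stays wide. Compound 4 is estimated at 18 mL/min/kg (expected range 6 mL/min/kg to 50 mL/min/kg).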

Compound 4, clearance: 0.62 mL/min/kg
Compound 4: middle estimate off by 29-fold (1.46 log units), on the high side, and the stated range ends above it.
By their numbers in this assay, from the lowest: compounds 2 and 4 (each within the scatter of the next); then compound 3; then compound 1.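

In this assay, for the compounds shown here, the group on the sulfonyl sulfur turns out to matter a great deal: cyclopentyl in place of 4-fluorophenyl gives a 19-fold lower number from compound 3 to compound 4 (1.29 log units; beyond the scatter), a change that no earlier pair covered. Going by these compounds alone, with cyclopentyl held constant, bringing in the fluoro alone gives a 42-fold lower number from compound 1 to compound 4 (1.62 log units; beyond the scatter), so the earlier exchange of fluoro for chloro is no longer the only single change with a large step. No measurement shown offers an explanation for either step.

As far as these compounds go, what an amine or a longer alkyl chain on the sulfonyl sulfur would give in this assay remains open. From the compounds shown here alone, it also remains open whether cyclopentyl and 4-fluorophenyl would differ in the same direction and by a similar amount with chloro in place of fluoro on the aromatic carbon.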